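A few compounds are considered here, and "the series" means these few. Any claim that something is new, unique, unknown or untested is made for them only; others in the source may bear on it.

Of the compounds shown here, three sharing one core have been measured in a functional assay on LNCaP cells (Homo sapiens) for antiproliferative activity, read by fluorescence and propidium iodide staining, with a stated time of 96 h; on this read-out lower numbers stand for stronger inhibition and higher numbers for weaker inhibition. Compound 1 `O=C(Nc1cc(C(F)(F)F)cc(C(F)(F)F)c1)c1ccc(Sc2ccc(O)cc2)cc1` gives 2390 nM, the lowest of the three numbers. Compound 2 `O=C(Nc1ccc(S(F)(F)(F)(F)F)cc1)c1ccc(Sc2ccc(O)cc2)cc1` gives 4860 nM, and compound 3 `O=C(Nc1ccc(C(F)(F)F)cc1)c1ccc(Sc2ccc(O)cc2)cc1` gives 8300 nM; between those two, a 1.7-fold higher number from compound 2 to compound 3 (0.23 log units; within the scatter). Compound 4 `O=C(Nc1cccc(C(F)(F)F)c1)c1ccc(Sc2ccc(O)cc2)cc1` is not yet measured; it differs from compound 1 by hydrogen in place of trifluoromethyl on an aromatic carbon. Going by the values given here, no measured step removes a trifluoromethyl group, so the only guide is that compound 3, which also carries a single trifluoromethyl group, gives 8300 nM, a weaker result than compound 1. Compound 4 is therefore expected to land near that level, with a 2.9-fold higher number from compound 1 to compound 4 (0.47 log units; beyond the scatter) anticipated as a weakening. The estimate for compound 4 is 7000 nM, between 3000 nM and 16000 nM.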

Compound 4, half-maximal inhibitory concentration: 9660 nM
Compound 4: the middle estimate sits 1.4-fold (0.14 log units) below what was measured, within the range that was stated.
By their numbers in this assay, from the lowest: compound 1; then compounds 2, 3 and 4 (each within the scatter of the next).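

Putting hydrogen in place of one trifluoromethyl group gives a 4.0-fold higher number from compound 1 to compound 4 (0.61 log units; beyond the scatter). Going by these compounds alone, this is the only measured step at this position, and it shows that the second trifluoromethyl group of compound 1 matters here: the step is modest but lies beyond the usual scatter, and the trifluoromethyl group that remains does not keep the number of compound 1.

As far as these compounds go, whether a methyl group, a chlorine, a nitrile or an amine at this place would keep that number stays open. Nothing available accounts for the size of this step.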